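The source may hold more compounds than are shown below. What is called first, only, known or untested is meant among the compounds shown, and "the series" means these compounds.

Measured so far:
compound 1, `CCOC(=O)N1CCC(=NNC(=O)c2ccc(C(F)(F)F)cc2)CC1`, in a functional assay on A549 cells (Homo sapiens) for cytotoxicity, read by MTT assay, with a stated time of 24 h (on this read-out lower numbers stand for stronger inhibition and higher numbers for weaker inhibition), compound 1 gives 37100000 nM
compound 2, `CCOC(=O)N1CCC(=NNC(=O)c2ccc([N+](=O)[O-])cc2[N+](=O)[O-])CC1`, in this assay compound 2 gives 27300000 nM
compound 3, `O=C(NN=C1CC(c2ccccc2)NC(c2ccccc2)C1)c1ccccc1`, in this assay compound 3 gives > 400000 nM

The value of compound 3 is a limit of the assay and not a number: the limit of > 400000 nM in this assay, at which 1 of the 3 values shown sits. Compound 1 and compound 2 give numbers; where compound 3 stands relative to them cannot be read from a limit.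

Compound 4, `Cc1ccc(C(=O)NN=C2CC(c3ccccc3)NC(c3ccccc3)C2)cc1`, differs from compound 3 by methyl in place of hydrogen on an aromatic carbon. Within the data shown here, no step between measured compounds is available to size this change. In this assay the step from compound 3 to compound 4 is expected to be none beyond the scatter, estimated as a step that the limit leaves unreadable from compound 3 to compound 4. Compound 4 is therefore expected to give about 600000 nM, in the range 200000 nM to 3000000 nM, most likely again reported only as a limit.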

Compound 4, half-maximal inhibitory concentration: > 400000 nM
Compound 4 gave a limit, no number; the forecaster's own chance of this, stated with the estimate: 75%; the middle value lies beyond the limit too.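

In this assay compound 3 gives > 400000 nM, a limit. Among these compounds, compound 4 gives > 400000 nM, also a limit, so no step between compound 3 and compound 4 can be read. As far as these compounds go, what methyl in place of hydrogen on an aromatic carbon does to the read-out remains open.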